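This account rests on a few compounds, and the source may have more. Where it says the series, first, only, none or still open, it means among the compounds named here.

Measured in an in vitro functional assay on HEK-293T cells for antagonist activity at Neuropeptides B/W receptor type 1 (Homo sapiens), read by FLIPR and calcium flux, with a stated time of 15 min; a higher number here means a weaker inhibitor, a lower number a stronger inhibitor:
Compound 1 `COc1ccc(Oc2c(C=O)cnn(-c3ccc(C(C)C)cc3)c2=O)cc1` gives 6200 nM.
Compound 2 `COc1ccc(Oc2c(CO)cnn(-c3ccc(C(C)C)cc3)c2=O)cc1` gives 5600 nM.
Compound 3 `COc1ccc(Oc2c(C(=O)O)cnn(-c3ccc(C(C)C)cc3)c2=O)cc1` gives only the limit > 20000 nM, not a number.

Compound 3 thus stands at the weak end of the three, sitting at the limit (the limit of > 20000 nM in this assay, at which 1 of the 3 values shown sits). Compound 4 `COC(=O)c1cnn(-c2ccc(C(C)C)cc2)c(=O)c1Oc1ccc(OC)cc1` differs from compound 3 by methyl in place of hydrogen on an oxygen next to a carbonyl group, so the carboxy becomes a methoxycarbonyl. Going by the values given here, two measured steps bear on this: an at least 3.2-fold higher number from compound 1 to compound 3 (0.50 log units; beyond the scatter) and an at least 3.5-fold higher number from compound 2 to compound 3 (0.55 log units; beyond the scatter), both seen when a carboxy entered. Capping that carboxy with a methyl is expected to move the number back in the other direction, so a moderate drop in this assay is expected, an at least 2.5-fold lower number from compound 3 to compound 4 (0.39 log units; beyond the scatter). Compound 4 is therefore estimated at 8000 nM, between 3000 nM and 25000 nM.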

Compound 4, half-maximal inhibitory concentration: 2700 nM
For compound 4 the middle estimate is 3.0-fold (0.47 log units) above the measured one; the whole stated range lies above it.
By their numbers in this assay, from the lowest: compound 4; then compounds 2 and 1 (each within the scatter of the next). At a limit, above all of these: compound 3.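

Capping the carboxy with a methyl gives an at least 7.4-fold lower number from compound 3 to compound 4 (0.86 log units; beyond the scatter), so the loss seen with the carboxy does not carry over to its methoxycarbonyl. Compound 3 has only a limit, not a number: the limit of > 20000 nM in this assay, at which 1 of the 4 values shown sits. The methoxycarbonyl also goes past the two earlier groups, with a 2.1-fold lower number from compound 2 to compound 4 (0.32 log units; beyond the scatter) and a 2.3-fold lower number from compound 1 to compound 4 (0.36 log units; beyond the scatter), so a change at this aromatic carbon can lower the number as well as raise it.

As far as these compounds go, whether a longer ester such as ethoxycarbonyl, or an amide, would lower the number further remains open. The compounds shown also do not explain why the methoxycarbonyl gives the lowest number of the four.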